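A New Group Enters Where the Chloro Left

A few compounds are considered here, and "the series" means these few. Any claim that something is new, unique, unknown or untested is made for them only; others in the source may bear on it.

Measured so far in a functional assay on HCT-15 cells (Homo sapiens) for cytotoxicity, read by sulforhodamine B assay, with a stated time of 48 h; a lower number here means that less compound is tolerated, a higher number that more compound is tolerated:
Compound 1 `ClCc1ccccc1Cn1cnc2c(Cl)nc(Cl)nc21` gives 4780 nM.
Compound 2 `ClCc1ccccc1Cn1cnc2c(Cl)ncnc21` gives 43700 nM.
Compound 3 `ClCc1cccc(Cn2cnc3nc(Cl)nc(Cl)c32)c1` gives 4570 nM.

Compound 2 stands highest of the three in this assay; compound 1 and compound 3 both sit well below it, so compound 2 is the one the cells tolerate best. Going by the values given here, the only single-point step among the measured compounds, a 9.1-fold higher number from compound 1 to compound 2 (0.96 log units; beyond the scatter), shows that taking away a chloro group from an aromatic carbon of the shared core raised the number considerably. Compound 4 `Nc1nc(Cl)c2ncn(Cc3ccccc3CCl)c2n1` returns to that same carbon with a different group: amino in place of hydrogen on an aromatic carbon, on an aromatic carbon of a six-membered aromatic ring with 2 nitrogen, between two ring nitrogen atoms, meta to a chloro group. Among the compounds with values here, no measured step tells what an amino group does here; the step from compound 1 to compound 2 only shows that this place matters. A partial return towards the lower numbers is therefore expected, with wide uncertainty. For compound 4 the expected value is 20000 nM, within 5000 nM to 80000 nM. That expectation amounts to a 2.2-fold lower number from compound 2 to compound 4 (0.34 log units; beyond the scatter).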

Compound 4, concentration lethal to 50% of the cells: > 100000 nM
Compound 4 ended at the assay's limit; the forecaster's own chance of this, stated with the estimate: 10%; middle value at least 5.0-fold (0.69 log units) away from the limit.
By their numbers in this assay, from the lowest: compounds 3 and 1 (each within the scatter of the next); then compound 2. At a limit, above all of these: compound 4.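

In this assay compound 4 gives > 100000 nM, which is a limit of the assay and not a number. On this aromatic carbon, between two ring nitrogen atoms, amino in place of hydrogen gives an at least 2.2-fold higher number from compound 2 to compound 4 (0.35 log units; beyond the scatter), and amino in place of chloro gives an at least 20-fold higher number from compound 1 to compound 4 (1.32 log units; beyond the scatter). Going by these compounds alone, the earlier compounds showed only that losing the chloro group raised the number, whereas these steps show that the group placed here also counts: amino does not bring the number back towards that of compound 1 but carries it past that of compound 2.

As far as these compounds go, how far compound 4 lies beyond the limit stays unknown, so both steps give only a minimum size. From the compounds shown here alone, whether a methyl group, a methoxy group or a larger amine on this carbon would behave like amino or like chloro also stays open.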